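Adding methyl to compound 2: working notes

This account rests on a few compounds, and the source may have more. Where it says the series, first, only, none or still open, it means among the compounds named here.

Measured so far in a functional assay on RKO cells (Homo sapiens) for cytotoxicity, read by resazurin assay, with a stated time of 72 h; a lower number here means a stronger inhibitor, a higher number a weaker inhibitor (read-out: half-maximal inhibitory concentration):
- compound 1 `Cc1nc2ccccc2n1-c1csc(Nc2cccc(Br)c2)n1` gives 85000 nM
- compound 2 `Brc1ccc(Nc2nc(-n3cnc4ccccc43)cs2)cc1` gives > 100000 nM as a limit

Compound 2 has no number on this scale, and its reading of > 100000 nM is a limit of the assay. Its true position can only be placed by that limit, so any step away from it will be loosely defined.

The next compound is compound 3 `Cc1nc2ccccc2n1-c1csc(Nc2ccc(Br)cc2)n1` and it differs from compound 2 at one place. The change methyl in place of hydrogen on an aromatic carbon is methyl in place of hydrogen on an aromatic carbon, between two ring nitrogen atoms.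

Within the data shown here, compound 1 also bears this methyl and gives a measured 85000 nM in this assay as the only number available, so the expectation rests on it. A small move toward stronger inhibition is expected, with the estimated step of an at least 1.4-fold lower number from compound 2 to compound 3 (0.15 log units; that floor lies within the scatter) not clearly beyond the usual scatter. Another reading at the limit remains possible.

Compound 3 is estimated at 70000 nM with an expected range from 25000 nM to 100000 nM in this measurement.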

Compound 3, half-maximal inhibitory concentration: 60000 nM
The estimate for compound 3 lay 1.2-fold (0.07 log units) above the measured number; the measured number falls inside the stated range.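

In this assay, methyl in place of hydrogen on an aromatic carbon, between two ring nitrogen atoms, gives an at least 1.6-fold lower number from compound 2 to compound 3 (0.22 log units; that floor lies within the scatter), so this position yields a measured number with methyl, but the step's floor does not clear the usual scatter. Compound 2 carries a limit and not a number, so the full size of this step cannot be read: the limit of > 100000 nM in this assay, at which 1 of the 3 values shown sits. With methyl present, 4-bromophenyl in place of 3-bromophenyl on a nitrogen on an aromatic ring gives a 1.4-fold lower number from compound 1 to compound 3 (0.15 log units; within the scatter), so this pair cannot be told apart in this assay, and the change of bromophenyl group shows no effect that can be read here.

The compounds shown leave open whether an ethyl group, an amine or a methoxy group at this same place would move the number clearly beyond the scatter. Among these compounds, they also leave open whether the methyl step would read the same with 3-bromophenyl in place of 4-bromophenyl, as the single step here rests on one pair and a limit.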